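The source may report more compounds than this note shows. Statements on the series, on what has been measured and on what is new or still open speak of the compounds shown alone.

Working notes on the series. The shared core is shown by compound 1 `CCC(Oc1ccc(-n2cc(C(F)(F)F)cn2)cc1)c1ccc(C(=O)NCCC(=O)O)cc1`, compound 2 `CCCC(Oc1ccc(-n2cc(F)cn2)cc1)c1ccc(C(=O)NCCC(=O)O)cc1` and compound 3 `CCCC(Oc1ccc(-n2cccn2)cc1)c1ccc(C(=O)NCCC(=O)O)cc1`. In a functional assay on cells for antagonist activity at Glucagon receptor (Homo sapiens), read by cAMP accumulation, in the presence of a further agent that is not named here (on this read-out lower numbers stand for stronger inhibition and higher numbers for weaker inhibition), compound 2 gives 10000 nM. For compound 1 the assay reports only a limit, > 22000 nM. For compound 3 the assay likewise reports only a limit, > 55000 nM, which places compound 3 at the weak end of the numbers shown, with no exact figure. Compound 4 `CCCC(Oc1ccc(-n2cc(C)cn2)cc1)c1ccc(C(=O)NCCC(=O)O)cc1` is not yet measured and differs from compound 3 by methyl in place of hydrogen on an aromatic carbon. Among the compounds with values here, the single measured step at the same place is an at least 5.5-fold higher number from compound 2 to compound 3 (0.74 log units; beyond the scatter), showing that a small substituent on that ring carbon can move the read-out, though because the limit of > 55000 nM in this assay, at which 1 of the 3 values shown sits, is a limit the full size of that step is unknown. Methyl is not fluoro, and the trifluoromethyl analogue compound 1, with its shorter chain, also sits at a limit, so direction is uncertain; a modest move toward lower numbers is the working guess. The expected step is an at least 2.2-fold lower number from compound 3 to compound 4 (0.34 log units; beyond the scatter). Compound 4 is therefore estimated at 25000 nM in this assay, within 8000 nM to 80000 nM.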

Compound 4, antagonist equilibrium constant: 11000 nM
Compound 4: middle estimate off by 2.3-fold (0.36 log units), on the high side, within the range that was stated.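

On the aromatic carbon two ring bonds from the ring nitrogen, methyl gives an at least 5.0-fold lower number from compound 3 to compound 4 (0.69 log units; beyond the scatter) in this assay and so a move to lower numbers from hydrogen is no longer seen with fluoro alone. Compound 3 sits at a limit, so the full size of that step cannot be read: the limit of > 55000 nM in this assay, at which 1 of the 4 values shown sits. Methyl in place of fluoro gives a 1.1-fold higher number from compound 2 to compound 4 (0.04 log units; within the scatter) and that lies within the scatter, so the two groups cannot be told apart on this read-out.

Going by these compounds, whether ethyl, methoxy or a nitrile on this ring carbon would read like methyl and fluoro remains open. Trifluoromethyl appears only in compound 1, on a shorter chain, so its effect at this position on the longer chain also stays open.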